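The source may report more compounds than this note shows. Statements on the series, on what has been measured and on what is new or still open speak of the compounds shown alone.

In a functional assay on MCF7 cells (Homo sapiens) for antiproliferative activity, read by MTT assay, with a stated time of 48 h (a higher number here means a weaker inhibitor, a lower number a stronger inhibitor), compound 2 `N#CC1=C(N)Oc2c(N)cc3nc4ccccc4nc3c2C12C(=O)N(Cc1cnnn1-c1ccc([N+](=O)[O-])cc1[N+](=O)[O-])c1ccccc12` gives 20900 nM, the lower of the two numbers recorded so far; its nearest neighbour, compound 1 `Cc1ccc(Cl)cc1-n1nncc1CN1C(=O)C2(C(C#N)=C(N)Oc3c(N)cc4nc5ccccc5nc4c32)c2ccccc21`, gives 43500 nM in this assay. Compound 3 `Cc1cc(C)c(-n2nncc2CN2C(=O)C3(C(C#N)=C(N)Oc4c(N)cc5nc6ccccc6nc5c43)c3ccccc32)c(C)c1` differs from compound 2 by 2,4,6-trimethylphenyl in place of 2,4-dinitrophenyl on an aromatic nitrogen. Among the compounds with values here, the only step that bears on this change is a 2.1-fold lower number from compound 1 to compound 2 (0.32 log units; beyond the scatter), and compound 3 carries an aryl group lacking nitro groups, as compound 1 does. He therefore expects a modest rise, a 1.9-fold higher number from compound 2 to compound 3 (0.28 log units; within the scatter), back toward the number of compound 1. His estimate for compound 3 in this assay is 40000 nM, with a range from 15000 nM to 110000 nM.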

Compound 3, half-maximal inhibitory concentration: > 50000 nM
Compound 3: no number, only a limit; the forecaster's own chance of this, stated with the estimate: 10%; middle value at least 1.2-fold (0.09 log units) from the limit.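

Compound 3 gives no number in this assay, only a limit: the limit of > 50000 nM in this assay, at which 1 of the 3 values shown sits. Even so, replacing 2,4-dinitrophenyl on the aromatic nitrogen with 2,4,6-trimethylphenyl gives a change that can be read, an at least 2.3-fold higher number from compound 2 to compound 3 (0.37 log units; beyond the scatter), so among these three compounds the lowest number belongs to the aryl group with nitro groups. Against 5-chloro-2-methylphenyl the reading sets no order, an at least 1.1-fold higher number from compound 1 to compound 3 (0.06 log units; that floor lies within the scatter).

On these data alone, it remains open whether both nitro groups are needed, and how an aryl group with a single nitro group would compare. As far as these compounds go, how an amine or a carboxylic acid on this aryl ring would read is also open.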